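This account rests on a few compounds, and the source may have more. Where it says the series, first, only, none or still open, it means among the compounds named here.

Going by the values given here, compound 1 `CC(C)c1c(C(=O)NCc2cccc(F)c2F)nn(-c2ccc(F)cc2)c1OC[C@@H](O)C[C@@H](O)CC(=O)O` stands as the lowest of the two numbers so far in a functional assay on L6 cells (Rattus norvegicus) for inhibition (on this read-out lower numbers stand for stronger inhibition and higher numbers for weaker inhibition), where compound 1 gives 120 nM. Its nearest neighbour is compound 2 `CC(C)c1c(C(=O)NCc2ccccc2Cl)nn(-c2ccc(F)cc2)c1OC[C@@H](O)C[C@@H](O)CC(=O)O`, which in this assay gives 8450 nM; that step, a 70-fold higher number from compound 1 to compound 2 (1.85 log units; beyond the scatter), shows how sharply the read-out responds to a change at the benzyl group. Compound 3 `CC(C)c1c(C(=O)N(C)Cc2ccc(F)c(F)c2)nn(-c2ccc(F)cc2)c1OC[C@@H](O)C[C@@H](O)CC(=O)O` differs from compound 1 by (3,4-difluorobenzyl)(methyl)amino in place of (2,3-difluorobenzyl)amino on a carbonyl carbon. Both the ring substitution and the amide hydrogen change at once, so for compound 3 a step of comparable size is expected: a 33-fold higher number from compound 1 to compound 3 (1.52 log units; beyond the scatter). For compound 3 the estimate is 4000 nM, within 700 nM to 20000 nM.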

Compound 3, half-maximal inhibitory concentration: 4570 nM
For compound 3 the middle estimate is 1.1-fold (0.06 log units) below the measured one; low and high end bracket the measured number.
By their numbers in this assay, from the lowest: compound 1; then compounds 3 and 2 (each within the scatter of the next).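

In this assay, the move to (3,4-difluorobenzyl)(methyl)amino on the carbonyl carbon gives a 38-fold higher number from compound 1 to compound 3 (1.58 log units; beyond the scatter), a large step like the one seen with the 2-chlorophenyl change. Replacing (2-chlorobenzyl)amino with the same group gives a 1.8-fold lower number from compound 2 to compound 3 (0.27 log units; within the scatter), so of these three compounds only compound 1, with (2,3-difluorobenzyl)amino, stands apart. No evidence is available that accounts for this. As far as these compounds go, compound 3 changes both the fluorine placement and the amide hydrogen, so the share of each in the step stays open. The (3,4-difluorobenzyl)amino group on the same carbonyl carbon would separate the two.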